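From trifluoromethyl to bromo on a shared core

A few compounds are considered here, and "the series" means these few. Any claim that something is new, unique, unknown or untested is made for them only; others in the source may bear on it.

compound 1 `O=C(Nc1cccc(C(F)(F)F)c1)c1cc(Cl)ccc1O` – 5900 nM
compound 2 `O=C(Nc1ccc(C(F)(F)F)c(C(F)(F)F)c1)c1cc(Cl)ccc1O` – 4900 nM

In an ADME assay on cells (Macrophage, Mus musculus) for cytotoxicity, read by resazurin assay, with a stated time of 3 days (on this read-out lower numbers stand for stronger inhibition and higher numbers for weaker inhibition), compound 1 gives 5900 nM. Among the compounds with values here, it has only one measured neighbour, and the comparison reads a 1.2-fold lower number from compound 1 to compound 2 (0.08 log units; within the scatter). Compound 1 therefore stands level with compound 2, and the two numbers set no order.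

Compound 3 `O=C(Nc1cccc(Br)c1)c1cc(Cl)ccc1O` has yet to be measured. It differs from compound 1 at one place: bromo in place of trifluoromethyl on an aromatic carbon. This is bromo in place of trifluoromethyl on an aromatic carbon, meta to a large group, while the rest of the core of compound 1 stays the same.

Within the data shown here, no measured step makes this exchange. Among the measured compounds shown here, the only step with any bearing is the one to compound 2, where a trifluoromethyl took the place of hydrogen on an aromatic carbon, and a 1.2-fold lower number from compound 1 to compound 2 (0.08 log units; within the scatter) stayed small. That is thin evidence, but it gives no reason to expect a large shift in this assay in either direction.

The expected change is a 1.2-fold lower number from compound 1 to compound 3 (0.07 log units; within the scatter), which means no step beyond the scatter. For compound 3 the estimated value is 5000 nM, with an expected range of 2500 nM to 10000 nM.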

Compound 3, half-maximal inhibitory concentration: 5700 nM
Compound 3: middle estimate off by 1.1-fold (0.06 log units), on the low side; measured number inside the range.
By their numbers in this assay, from the lowest: compounds 2, 3 and 1 (each within the scatter of the next).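

Until now, the only step shown had added a trifluoromethyl in place of hydrogen on an aromatic carbon, leaving the first trifluoromethyl in place, so the group on this carbon, meta to a large group, had not itself been exchanged. Compound 3 supplies that exchange, and in this assay the change to bromo gives a 1.0-fold lower number from compound 1 to compound 3 (0.01 log units; within the scatter). At this position, a substituent of 4 heavy atoms therefore gives way to one of 1 heavy atom with no step beyond the scatter, though no measurement here bears on why the read-out behaves this way.

All the steps shown lie within the scatter, so they leave open which change to the shared core, if any, would produce a step beyond it in this assay. It also remains open whether an amine, a carboxylic acid or a longer chain on this aromatic carbon would stay within the scatter as bromo does, since trifluoromethyl and bromo are the only groups shown at this position.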